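The compounds below may be only part of what the source reports. "The series", "measured", "known", "first", "only" and "open" are said of these compounds alone.

Compounds measured so far:

Compound 1 `O=C(CN(C(=O)c1ccc(Cl)cc1)C1CCCCC1)Nc1cc(F)cc(F)c1`, in an assay on HEK293 cells for inhibition of sodium- and chloride-dependent glycine transporter 1 (Homo sapiens), read by scintillation proximity assay (on this read-out lower numbers stand for stronger inhibition and higher numbers for weaker inhibition), compound 1 gives 631 nM.
Compound 2 `CN1CCC(C(=O)N(CC(=O)Nc2cc(F)cc(F)c2)C2CCCCC2)CC1`, in this assay compound 2 reaches only the limit of > 25100 nM, a limit of the assay rather than a number.
Compound 3 `O=C(CN(C(=O)C1CCCCC1)C1CCCCC1)Nc1cc(F)cc(F)c1`, in this assay compound 3 gives 6310 nM.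

Among the numbers shown, compound 3 stands highest; its nearest neighbour is compound 1, with a 10-fold higher number from compound 1 to compound 3 (1.00 log units; beyond the scatter). The step from compound 2 to compound 3 is known only as an at least 3.9-fold lower number from compound 2 to compound 3 (0.59 log units; beyond the scatter), since compound 2 sits at a limit (the limit of > 25100 nM in this assay, at which 1 of the 3 values shown sits).

Compound 4 `O=C(CN(C(=O)c1ccccc1Cl)C1CCCCC1)Nc1cc(F)cc(F)c1` differs from compound 3 in one place: 2-chlorophenyl in place of cyclohexyl on a carbonyl carbon.

Within the data shown here, the only measured step that bears on this change is the one from compound 1 to compound 3, where a chlorophenyl on the carbonyl carbon gave way to cyclohexyl and the number rose by a 10-fold higher number from compound 1 to compound 3 (1.00 log units; beyond the scatter). Compound 4 reverses the ring type but moves the chlorine to a different place on the phenyl. He therefore expects a lower number in this assay, a step of roughly a 5.3-fold lower number from compound 3 to compound 4 (0.72 log units; beyond the scatter), though the shifted chlorine leaves the size uncertain. Compound 4 is estimated at 1200 nM, between 300 nM and 5000 nM.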

Compound 4, half-maximal inhibitory concentration: 20000 nM
Estimate against measurement, compound 4: 17-fold (1.22 log units) below; measured number above the stated range.
By their numbers in this assay, from the lowest: compound 1; then compound 3; then compound 4. At a limit, above all of these: compound 2.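

The result shows that a chlorophenyl on this carbonyl carbon does not by itself give the lower number: where the chlorine sits decides it, as in this assay 2-chlorophenyl in place of 4-chlorophenyl gives a 32-fold higher number from compound 1 to compound 4 (1.50 log units; beyond the scatter). The earlier step from compound 1 to compound 3 could be read as favouring an aromatic ring over cyclohexyl, but the aromatic ring of compound 4 does worse than the cyclohexyl, with a 3.2-fold higher number from compound 3 to compound 4 (0.50 log units; beyond the scatter). The comparison with the limit of compound 2 goes no further than an at least 1.2-fold lower number from compound 2 to compound 4 (0.09 log units; that floor lies within the scatter), compound 2 standing at a limit: the limit of > 25100 nM in this assay, at which 1 of the 4 values shown sits.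

The compounds shown leave open where a plain phenyl would fall on this carbonyl carbon. They also leave open whether a methoxy or a nitrile in place of the chlorine of compound 1 would keep its number.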